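A few compounds are considered here, and "the series" means these few. Any claim that something is new, unique, unknown or untested is made for them only; others in the source may bear on it.

Compound 1 `CCCCC(N)c1cc(C(F)(F)F)ccc1N1CCN(C(=O)CCc2ccc(Cl)cc2Cl)CC1` gives 190 nM in an assay on HEK293 cells for displacement of a labelled ligand from Melanocortin receptor 4 (Homo sapiens); on this read-out higher numbers stand for weaker inhibition and lower numbers for stronger inhibition.
Compound 2 `CC(C)C[C@H](N)c1cc(C(F)(F)F)ccc1N1CCN(C(=O)CCc2ccccc2O)CC1` gives 3300 nM.
Compound 3 `CC(C)C[C@H](N)c1cc(C(F)(F)F)ccc1N1CCN(C(=O)CCc2c[nH]c3ccccc23)CC1` gives 640 nM.

Among these three, compound 1 has the lowest number in this assay, with compound 3 the nearest and compound 2 the furthest. Compound 4 `CCN[C@@H](CC(C)C)c1cc(C(F)(F)F)ccc1N1CCN(C(=O)CCc2ccc(Cl)cc2Cl)CC1` has not yet been measured. It differs from compound 1 in one place: 1-(ethylamino)-3-methylbutyl in place of 1-aminopentyl on an aromatic carbon. Within the data shown here, the only measured step, a 5.2-fold lower number from compound 2 to compound 3 (0.71 log units; beyond the scatter), concerns the group beyond the carbonyl, not the side chain changed here, so it does not bear on this change. Compounds 2 and 3 differ from compound 4 at both ends of the molecule, so their values cannot be split between the two changes. Among the measured compounds shown here, with no direct precedent, compound 4 is expected to stay close to compound 1, the step of a 1.3-fold higher number from compound 1 to compound 4 (0.12 log units; within the scatter) being within the scatter or at most modest. Compound 4 is therefore estimated at 250 nM, with a range from 60 nM to 1000 nM.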

Compound 4, inhibition constant: 170 nM
Compound 4: the middle estimate sits 1.5-fold (0.17 log units) above what was measured; the measured number falls inside the stated range.
By their numbers in this assay, from the lowest: compounds 4 and 1 (each within the scatter of the next); then compound 3; then compound 2.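

In this assay, placing 1-(ethylamino)-3-methylbutyl in place of 1-aminopentyl on this aromatic carbon gives a 1.1-fold lower number from compound 1 to compound 4 (0.05 log units; within the scatter), so the two compounds cannot be told apart. This position therefore accepts the larger group, with an ethyl on its nitrogen and a branched chain, without a step beyond the scatter. No supporting evidence explains this result. As far as these compounds go, the ethyl and the branching arrive together, so their separate contributions remain unknown. Also open, from the compounds shown here alone, is how a longer chain, or a carboxylic acid in place of the amine, would read here.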